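A methyl on the amide-type nitrogen of compound 2

This account rests on a few compounds, and the source may have more. Where it says the series, first, only, none or still open, it means among the compounds named here.

In a functional assay on the whole organism for agonist activity, with Mus musculus as the target (on this read-out lower numbers stand for an effect already at smaller amounts and higher numbers for an effect only at larger amounts of compound), compound 1 (`CC(=O)NCC#CCn1cncc1C`) reports only a limit (> 100 mg/kg). Compound 2 (`COC(=O)NCC#CCn1cncc1C`) also reports only a limit in this assay (> 100 mg/kg), so it has no actual number on this read-out. Both compounds therefore rest at the same ceiling (the limit of > 100 mg/kg in this assay, at which 2 of the 2 values shown sit).

Compound 3 (`COC(=O)N(C)CC#CCn1cncc1C`) keeps the rest of compound 2 and changes one place (methyl in place of hydrogen on an amide-type nitrogen), with methyl in place of hydrogen on an amide-type nitrogen. Among the compounds with values here, only one measured step is at hand (a step that the two limits leave unreadable from compound 1 to compound 2). It concerns a carbonyl carbon rather than this nitrogen, and it offers no size to carry over. No measured change on that nitrogen exists, so the expectation rests on the limit shared by compound 1 and compound 2, and no direction is favoured. The expected step is one without a firm size (a step that the limit leaves unreadable from compound 2 to compound 3). Compound 3 is expected to stay near that ceiling and will most likely return a limit again. For compound 3 the estimated value is 120 mg/kg, with an expected range from 40 mg/kg to 300 mg/kg.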

Compound 3, dose for half-maximal effect: > 100 mg/kg
Compound 3: no number, only a limit (the forecaster's own chance of this, stated with the estimate: 75%); the middle value is on the limit's open side.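

Compound 3 gives only a limit in this assay just as compound 2 does, so no step can be read between these two compounds, nor between compound 1 and compound 2. The compounds shown leave open what dose, if any, gives a half-maximal effect, and whether the methyl on the amide-type nitrogen changes it.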